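Ethyl Ester of the Methoxy Cinnamate: Expected Cytotoxicity

The compounds below may be only part of what the source reports. "The series", "measured", "known", "first", "only" and "open" are said of these compounds alone.

Two acids have been measured. Compound 1 `Cc1nc(C)c(C(=O)Oc2ccccc2/C=C/C(=O)O)nc1C` gives 45.7% in a functional assay on EA.hy 926 cells (Homo sapiens) for cytotoxicity, read by MTT assay, with stated times of 24 h and 12 h, tested at 12.5 uM (a lower number here means a weaker effect, a higher number a stronger effect of the compound at the concentration tested), and compound 2 `COc1ccc(/C=C/C(=O)O)c(OC(=O)c2nc(C)c(C)nc2C)c1` gives 39.7% in the same this assay; the step of a number 6 percentage points lower from compound 1 to compound 2 (within the scatter) consists of methoxy in place of hydrogen on an aromatic carbon. Compound 2 thus holds the lower of the two numbers, but the gap to compound 1 lies within the scatter, so neither compound can be called the stronger.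

Compound 3 `CCOC(=O)/C=C/c1ccc(OC)cc1OC(=O)c1nc(C)c(C)nc1C` is the ethyl ester of compound 2. The change is ethyl in place of hydrogen on an oxygen next to a carbonyl group. Going by the values given here, no measured step touches the acid end of the molecule, so the expectation for compound 3 rests only on the two nearby acid values and on the absence of contrary evidence. Compound 3 is therefore expected to give a number close to that of compound 2, an estimated 40% in this assay with a range from 25% to 55%, a step of a number 0.3 percentage points higher from compound 2 to compound 3 (within the scatter) that is expected to stay within the scatter.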

Compound 3, a percentage reported as activity, at one concentration (the size of the read-out at that concentration, not a potency): -57.6%
Estimate against measurement, compound 3: 97.6 percentage points above; measured number outside the range, below it.
By their numbers in this assay, from the lowest: compound 3; then compounds 2 and 1 (each within the scatter of the next).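

The acid end of the molecule proves far more responsive than the aromatic position varied earlier, whose step stayed within the scatter: in this assay, the change from carboxy to ethoxycarbonyl gives a number 97.3 percentage points lower from compound 2 to compound 3 (beyond the scatter). Compound 3 gives -57.6%, a negative number, whereas compound 2 gave a positive one, so this single change alters the sign of the read-out as well as its size. Nothing available explains this drop.

Going by these compounds, whether the drop belongs to ethyl alone, or would also appear with a methyl ester, a longer chain or an amide on this carbonyl group, remains open. On these data alone, it is equally open whether the same ethyl ester without the methoxy group would behave like compound 3.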